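The source may hold more compounds than are shown below. What is called first, only, known or untested is meant among the compounds shown, and "the series" means these compounds.

Measured so far:
- compound 1 `CN(C)c1ccc(C2CC(c3ccccn3)=NN2c2ccccc2)cc1` gives 35% in a functional assay on the whole organism (strain Charles Foster albino) for inhibition, with Rattus norvegicus as the target, read by paw edema, with stated times of 30 min and 3 h, at a dose of 50 mg/kg by the oral route; on this read-out lower numbers stand for less inhibition and higher numbers for more inhibition at the one dose given (going by the name of the read-out)
- compound 2 `CN(C)c1ccc(C2CC(c3ccccn3)=NN2)cc1` gives 18% in this assay

Within the data shown here, compound 1 stands highest of the two numbers measured in this assay; its nearest neighbour is compound 2, and the single measured step, a number 17 percentage points lower from compound 1 to compound 2 (beyond the scatter), is a modest one that lies beyond the scatter. That step swaps a phenyl on a ring nitrogen for hydrogen and says nothing about the pyridine ring.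

Compound 3 `CN(C)c1ccc(C2CC(c3cccnc3)=NN2c2ccccc2)cc1` is not yet measured. It differs from compound 1 in one place: pyridin-3-yl in place of pyridin-2-yl on a carbon with a double bond to nitrogen. The nitrogen within the six-membered ring is simply moved, the rest of the structure staying as in compound 1.

Among the measured compounds shown here, no measured step bears on this change. For the measured compounds named here, the only comparison in hand concerns the phenyl on the ring nitrogen, so there is no measured basis for expecting a step beyond the scatter in this assay in either direction. For compound 3 the expected outcome is a number 5 percentage points lower from compound 1 to compound 3 (within the scatter), a step within the usual scatter. Compound 3 is therefore estimated at 30%, with a likely range from 14% to 46%.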

Compound 3, a percentage reported as inhibition, in the whole organism at one dose (the size of the read-out at that dose, not a potency): 34%
For compound 3 the middle estimate is 4 percentage points below the measured one, and the stated range covers the measured number.
By their numbers in this assay, from the lowest: compound 2; then compounds 3 and 1 (each within the scatter of the next).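

In this assay, putting pyridin-3-yl in place of pyridin-2-yl on the carbon with a double bond to nitrogen gives a number 1 percentage points lower from compound 1 to compound 3 (within the scatter), so at this one dose the read-out does not separate these two placements of the nitrogen within the pyridine ring. Among these compounds, this is the first comparison to touch that ring, since the earlier step, a number 17 percentage points lower from compound 1 to compound 2 (beyond the scatter), concerned only the phenyl on the ring nitrogen, and it shows that not every single change to compound 1 moves the number beyond the scatter. No measurement at hand offers an explanation for this result.

On these data alone, it remains open whether the two pyridine placements would stay level at other doses or with hydrogen in place of the phenyl on the ring nitrogen, because a single pair at a single dose cannot settle either point. Also open, as far as these compounds go, is how pyridin-4-yl, or a ring carrying a carboxylic acid or an amine, would read at this same position on the shared core.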